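A few compounds are considered here, and "the series" means these few. Any claim that something is new, unique, unknown or untested is made for them only; others in the source may bear on it.

Measured so far:
compound 1 `Fc1cncc(OC[C@@H]2CCN2)c1` — 0.076 nM
compound 2 `FC(F)(F)c1cncc(OC[C@@H]2CCN2)c1` — 0.49 nM
compound 3 `CCc1cncc(OC[C@@H]2CCN2)c1` — 0.1 nM

In an assay on brain for binding affinity to Neuronal acetylcholine receptor; alpha4/beta2 (Rattus norvegicus), read by radioligand binding (on this read-out higher numbers stand for weaker inhibition and lower numbers for stronger inhibition), compound 3 holds the second highest of the three numbers. Its nearest neighbour is compound 1, and a 1.3-fold higher number from compound 1 to compound 3 (0.12 log units; within the scatter) lies within the scatter, so the two cannot be ordered. Its furthest neighbour is compound 2, and a 4.9-fold lower number from compound 2 to compound 3 (0.69 log units; beyond the scatter) is a modest step beyond the scatter.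

Compound 4 `NCc1cncc(OC[C@@H]2CCN2)c1` differs from compound 3 by amino in place of methyl on a saturated chain carbon bound to an aromatic carbon. Within the data shown here, no measured step touches the saturated chain carbon itself; the three known steps all swap groups on the aromatic carbon, and they range from no change beyond the scatter, in a 1.3-fold higher number from compound 1 to compound 3 (0.12 log units; within the scatter), to a modest shift, in a 6.4-fold higher number from compound 1 to compound 2 (0.81 log units; beyond the scatter). The step from compound 3 to compound 4 is therefore judged by analogy only, and a modest change in either direction is plausible. Compound 4 is expected to give 0.4 nM in this assay, within 0.07 nM to 2.5 nM, a step of a 4.0-fold higher number from compound 3 to compound 4 (0.60 log units; beyond the scatter) that is estimated, not measured.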

Compound 4, inhibition constant: 4.4 nM
Compound 4: middle estimate off by 11-fold (1.04 log units), on the low side; the whole stated range lies below it.
By their numbers in this assay, from the lowest: compounds 1 and 3 (each within the scatter of the next); then compound 2; then compound 4.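

In this assay, among these compounds, aminomethyl is the first group on this aromatic carbon to push the number clearly past the range set by fluoro, ethyl and trifluoromethyl. Among the compounds shown here, exchanging methyl for amino on the saturated chain carbon changes one heavy atom, yet it gives a 44-fold higher number from compound 3 to compound 4 (1.64 log units; beyond the scatter), a large step where the earlier steps were modest or within the scatter. Compound 4 also stands apart from the other two, with a 58-fold higher number from compound 1 to compound 4 (1.76 log units; beyond the scatter) and a 9.0-fold higher number from compound 2 to compound 4 (0.95 log units; beyond the scatter), so this position does not treat ethyl and aminomethyl alike, and nothing available explains the difference.

The compounds shown leave open whether hydroxymethyl or methoxymethyl would stay with ethyl or follow aminomethyl. They also leave open whether a dimethylaminomethyl group or a longer chain ending in an amine would give a number like that of compound 4.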